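Chlorine to iodine on the benzamide: what to expect

The compounds below may be only part of what the source reports. "The series", "measured", "known", "first", "only" and "open" are said of these compounds alone.

Measured in a functional assay on HepG2 cells (Homo sapiens) for inhibition, read by MTT assay; a higher number here means a weaker inhibitor, a lower number a stronger inhibitor:
Compound 1 `COc1cc2ncnc(Nc3ccc(NC(=O)c4ccccc4OC)cc3)c2cc1OC`: > 100000 nM, a limit of the assay and not a number
Compound 2 `COc1cc2ncnc(Nc3ccc(NC(=O)c4ccc(C(C)(C)C)cc4)cc3)c2cc1OC`: > 100000 nM, also a limit of the assay and not a number
Compound 3 `COc1cc2ncnc(Nc3ccc(NC(=O)c4ccccc4Cl)cc3)c2cc1OC`: 26000 nM

Of these three, only compound 3 has a true number, and the rest is the limit of > 100000 nM in this assay, at which 2 of the 3 values shown sit. Compound 4 `COc1cc2ncnc(Nc3ccc(NC(=O)c4cccc(I)c4)cc3)c2cc1OC` is still unmeasured. It carries 3-iodophenyl in place of 2-chlorophenyl on a carbonyl carbon.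

Going by the values given here, two measured steps bear on this change: an at least 3.8-fold lower number from compound 1 to compound 3 (0.58 log units; beyond the scatter), and an at least 3.8-fold lower number from compound 2 to compound 3 (0.58 log units; beyond the scatter). Neither is the change at hand, and both start from a limit, so they show only a minimum for how much the group on the carbonyl carbon can matter. They show that this group can shift the result, but not which way 3-iodophenyl will push it. No step beyond the scatter is therefore expected in this assay, though a rise towards the limit remains possible. The expected step is a 1.2-fold higher number from compound 3 to compound 4 (0.06 log units; within the scatter). Compound 4 is estimated at 30000 nM, with an expected range of 10000 nM to 90000 nM.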

Compound 4, half-maximal inhibitory concentration: 28000 nM
The estimate for compound 4 lay 1.1-fold (0.03 log units) above the measured number, within the range that was stated.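

In this assay, trading 2-chlorophenyl for 3-iodophenyl on the carbonyl carbon gives a 1.1-fold higher number from compound 3 to compound 4 (0.03 log units; within the scatter), so two rings that differ in their halogen and its place now read alike. Going by these compounds alone, the gap to the other two groups also reappears, with an at least 3.5-fold lower number from compound 2 to compound 4 (0.55 log units; beyond the scatter) and an at least 3.5-fold lower number from compound 1 to compound 4 (0.55 log units; beyond the scatter), which means compound 3 no longer stands alone as the only compound with a true number. Both of these steps are minimums, since compound 1 and compound 2 each sit at a limit of the assay and not a number: the limit of > 100000 nM in this assay, at which 2 of the 4 values shown sit.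

As far as these compounds go, whether 3-chlorophenyl or 2-iodophenyl would read the same stays open, so the halogen and its place on the ring cannot yet be told apart. Also open, from the compounds shown here alone, is whether an amine or a carboxylic acid on this ring would give a clearly lower number.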